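This account rests on a few compounds, and the source may have more. Where it says the series, first, only, none or still open, it means among the compounds named here.

Compound 3 `CC1=C(C(N)=O)C(c2ccoc2)NC(=O)N1` gives 2% in an assay on membranes from HeLa cells for displacement of a labelled ligand from adenosine receptor A3 (Homo sapiens), read by scintillation counting, with a stated time of 180 min, tested at 1 uM (on this read-out higher numbers stand for more inhibition at the one concentration tested (going by the name of the read-out) and lower numbers for less inhibition), the lowest of the three numbers recorded so far. Compound 1 `CC1=C(C(=O)C2CC2)C(c2ccoc2)NC(=O)N1` gives 16%, and compound 2 `CCN(CC)C(=O)C1=C(C)NC(=O)NC1c1ccco1` gives 19%. Compound 4 `CCN(CC)C(=O)C1=C(C)NC(=O)NC1c1ccoc1` has not yet been measured; it differs from compound 3 by diethylamino in place of amino on a carbonyl carbon. Among the measured compounds shown here, one measured step bears on this change: a number 14 percentage points lower from compound 1 to compound 3 (beyond the scatter), where a carbon-bearing group on that carbonyl was swapped for amino and the number fell. Moving the other way, from amino to diethylamino, a rise of similar size is expected, and compound 2, which also carries diethylamino on its carbonyl, gives 19%. Compound 4 is therefore expected to reach 17%, between 5% and 30%, a rise of a number 15 percentage points higher from compound 3 to compound 4 (beyond the scatter).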

Compound 4, a percentage reported as inhibition, at one concentration (the size of the read-out at that concentration, not a potency): 37%
Compound 4: the middle estimate sits 20 percentage points below what was measured; measured number outside the range, above it.
By their numbers in this assay, from the lowest: compound 3; then compounds 1 and 2 (each within the scatter of the next); then compound 4.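

In this assay, the carbonyl carbon proves a strong lever: diethylamino in place of amino gives a number 35 percentage points higher from compound 3 to compound 4 (beyond the scatter), and diethylamino in place of cyclopropyl gives a number 21 percentage points higher from compound 1 to compound 4 (beyond the scatter). The furan attachment also matters, since with diethylamino held constant, furan-3-yl in place of furan-2-yl gives a number 18 percentage points higher from compound 2 to compound 4 (beyond the scatter). Nothing measured here explains why either change raises the number. The compounds shown leave open how methylamino or a ring amine such as piperidine would behave on this carbonyl carbon. They also leave open what potency lies behind these single-concentration readings.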